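The source may report more compounds than this note shows. Statements on the series, on what has been measured and on what is new or still open speak of the compounds shown alone.

Compound 1 `O=c1cc(Cn2cc(CCCCl)nn2)c2ccc(O)cc2o1`: 59800 nM in a functional assay on SW-620 cells (Homo sapiens) for inhibition, read by MTT assay, with a stated time of 72 h; on this read-out higher numbers stand for weaker inhibition and lower numbers for stronger inhibition.
Compound 2 `CCCCCCc1cn(Cc2cc(=O)oc3cc(O)ccc23)nn1`: > 100000 nM, which is a limit of this assay.
Compound 3 `CCCCCCCCc1cn(Cc2cc(=O)oc3cc(O)ccc23)nn1`: 50900 nM in this assay.

Compound 3 holds the lowest of the two numbers, with compound 1 its nearest neighbour at a 1.2-fold lower number from compound 1 to compound 3 (0.07 log units; within the scatter). Compound 4 `O=c1cc(Cn2cc(CSC(=S)N3CCOCC3)nn2)c2ccc(O)cc2o1` departs from compound 3 by a group of 9 heavy atoms (5 carbon, 1 nitrogen, 1 oxygen, 2 sulfur; one six-membered non-aromatic ring with 2 hetero atoms) in place of a group of 7 heavy atoms (7 carbon; no ring), on a saturated chain carbon bound to an aromatic carbon. The measured steps, an at least 1.6-fold higher number from compound 1 to compound 2 (0.22 log units; that floor lies within the scatter) and an at least 1.9-fold lower number from compound 2 to compound 3 (0.29 log units; that floor lies within the scatter), concern only the length of the alkyl chain and never the entering group, so none of them speaks directly to this change. With every measured step inside the scatter, no shift beyond it is expected in this assay, though the estimate is wide. Compound 4 is therefore expected at 50000 nM, between 8000 nM and 150000 nM, a step of a 1.0-fold lower number from compound 3 to compound 4 (0.01 log units; within the scatter).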

Compound 4, half-maximal inhibitory concentration: >= 100000 nM
Compound 4: no number, only a limit; the forecaster's own chance of this, stated with the estimate: 30%; at least 2.0-fold (0.30 log units) between middle value and limit.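

In this assay, compound 4 is the only one shown with a six-membered non-aromatic ring and sulfur on the saturated chain carbon bound to an aromatic carbon, and its reading is a limit: the limit of >= 100000 nM in this assay, at which 1 of the 4 values shown sits.

The readable steps are an at least 1.9-fold higher number from compound 3 to compound 4 (0.29 log units; that floor lies within the scatter) and an at least 1.6-fold higher number from compound 1 to compound 4 (0.22 log units; that floor lies within the scatter), so this group gives no lower number here, but neither floor clears the scatter. The step from compound 2 joins two limits and cannot be read.

Going by these compounds, the true size of these steps remains open. So does whether an amine or a carboxylic acid at this place, or a chain longer than heptyl, would give a lower number in this assay.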